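The source may report more compounds than this note shows. Statements on the series, on what has been measured and on what is new or still open speak of the compounds shown alone.

Compound 1 `COc1cc(/C=C/C(=O)c2cccc(-n3cc(-c4ccccc4)[nH]c3=O)c2)ccc1O`: in a functional assay on MDA-MB-435 cells (Homo sapiens) for inhibition (on this read-out higher numbers stand for weaker inhibition of growth and lower numbers for stronger inhibition of growth), compound 1 gives 2140 nM.
Compound 2 `COc1ccc(-c2cn(-c3cccc(C(=O)/C=C/c4ccc(O)c(OC)c4)c3)c(=O)[nH]2)cc1`: in this assay compound 2 gives 3350 nM.

Compound 2 holds the highest of the two numbers, but its nearest neighbour, compound 1, lies only a 1.6-fold higher number from compound 1 to compound 2 (0.19 log units; within the scatter), so on these data the two cannot be told apart.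

Compound 3 `COc1cc(/C=C/C(=O)c2cccc(-n3cc(-c4ccc(Cl)cc4)[nH]c3=O)c2)ccc1O` differs from compound 2 in one place: chloro in place of methoxy on an aromatic carbon. Among the compounds with values here, only one measured step bears on this: the change from compound 1 to compound 2, which put a methoxy on that same aromatic carbon in place of hydrogen and gave a 1.6-fold higher number from compound 1 to compound 2 (0.19 log units; within the scatter). Replacing that methoxy by chloro therefore touches a position where the one known variation had no effect beyond the scatter. Within the data shown here, nothing among the measured compounds shows what a chloro in this position does, so the expectation rests on the flatness of the one known step.

The step from compound 2 to compound 3 is therefore expected to be a 1.3-fold lower number from compound 2 to compound 3 (0.11 log units; within the scatter), with no clear direction. Compound 3 is estimated at 2600 nM in this assay, with a range from 1200 nM to 5500 nM.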

Compound 3, concentration for 50% growth inhibition: 2250 nM
Estimate against measurement, compound 3: 1.2-fold (0.06 log units) above; the range from low to high includes it.
By their numbers in this assay, from the lowest: compounds 1, 3 and 2 (each within the scatter of the next).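

With chloro, this aromatic carbon, para to a large group, has now carried hydrogen, methoxy and chloro in this assay, and the earlier pair alone could not show whether the flat result would hold for a second substituent. Exchanging methoxy for chloro gives a 1.5-fold lower number from compound 2 to compound 3 (0.17 log units; within the scatter), and chloro in place of hydrogen gives a 1.1-fold higher number from compound 1 to compound 3 (0.02 log units; within the scatter), so neither the 4-methoxyphenyl to 4-chlorophenyl change nor the addition of chloro separates these compounds, and the three form a level set at this position. No independent measurement is available here to explain this level result.

Whether this tolerance extends to very different groups on the same carbon, such as an amine, a carboxylic acid or a longer alkyl chain, remains open, since hydrogen, methoxy and chloro are the only variations shown there. The compounds also leave open how growth inhibition would respond to changes elsewhere in the shared core, for example replacing its hydroxy group with an amine.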